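The source may report more compounds than this note shows. Statements on the series, on what has been measured and on what is new or still open speak of the compounds shown alone.

Measured so far in a toxicity assay on HepG2 2.2.15 cells (Homo sapiens) for cytotoxicity, read by CellTiter-Glo; on this read-out higher numbers stand for lower toxicity in this test and lower numbers for higher toxicity in this test:
- compound 1 `Cc1cnc(C2CC(=O)N(c3cnn4c3CN(C(=O)Nc3cc(F)c(F)c(F)c3)C(C3CC3)C4)C2)s1`: 96200 nM
- compound 2 `C[C@H]1Cn2ncc(N3CC(c4ccccc4)CC3=O)c2CN1C(=O)Nc1cc(F)c(F)c(F)c1`: 12800 nM

Compound 1 stands highest of the two numbers in this assay; compound 2 gives the lower number, and the gap between them lies beyond the scatter of this kind of measurement. Within the data shown here, the two compounds differ in more than one place, so no single structural step between measured compounds is available to calibrate against.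

Compound 3 `O=C1CC(c2ccccn2)CN1c1cnn2c1CN(C(=O)Nc1cc(F)c(F)c(F)c1)C(C1CC1)C2` is the next point in the series. It keeps the core of compound 1 and differs from it by pyridin-2-yl in place of 5-methyl-1,3-thiazol-2-yl on a saturated ring carbon. Among the measured compounds shown here, with no measured step of the same kind to go on, the change from compound 1 to compound 3 is expected to produce a small step in this assay, if any, most likely a modest decrease in the number or none beyond the scatter: a 1.4-fold lower number from compound 1 to compound 3 (0.14 log units; within the scatter). On that basis compound 3 is estimated at 70000 nM, with a range of 25000 nM to 150000 nM.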

Compound 3, half-maximal cytotoxic concentration: 96200 nM
Estimate against measurement, compound 3: 1.4-fold (0.14 log units) below, within the range that was stated.
By their numbers in this assay, from the lowest: compound 2; then compounds 1 and 3 (each within the scatter of the next).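

In this assay, among these compounds, the only single-place step reads no change at the digits printed from compound 1 to compound 3 (within the scatter), with pyridin-2-yl in place of 5-methyl-1,3-thiazol-2-yl on a saturated ring carbon of the five-membered non-aromatic ring. With the core of compound 1 held constant, this read-out does not separate a five-membered aromatic ring with 2 hetero atoms from a six-membered aromatic ring with 1 hetero atom at this position. No measured evidence bears on why these two groups read alike.

On these data alone, whether the same holds for a group without an aromatic ring at this carbon, such as an amine, a carboxylic acid or a longer alkyl chain, remains open. Compound 2 differs from compound 1 and compound 3 in more than one place, so its value cannot be tied to any single change.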